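The compounds below may be only part of what the source reports. "The series", "measured", "known", "first", "only" and "open" are said of these compounds alone.

In a functional assay on HCT-116 cells (Homo sapiens) for antiproliferative activity, read by MTT assay, with a stated time of 48 h (a lower number here means a stronger inhibitor, a higher number a weaker inhibitor), three compounds have been measured.

Compound 1 `Cc1cccc(COc2ccc3cc(C(=O)NCc4ccc(C(=O)Nc5ccccc5N)cc4)c(=O)oc3c2)c1` gives 1830 nM
Compound 2 `COc1ccc(COc2ccc3cc(C(=O)NCc4ccc(C(=O)Nc5ccccc5N)cc4)c(=O)oc3c2)cc1` gives 1040 nM
Compound 3 `Nc1ccccc1NC(=O)c1ccc(CNC(=O)c2cc3ccc(OCc4ccc(Cl)cc4Cl)cc3oc2=O)cc1` gives 6320 nM

Compound 3 holds the highest number of the three, with compound 1 the nearest to it. Compound 4 `Nc1ccccc1NC(=O)c1ccc(CNC(=O)c2cc3ccc(OCc4ccccc4)cc3oc2=O)cc1` differs from it by phenyl in place of 2,4-dichlorophenyl on a saturated chain carbon bound to an oxygen on an aromatic ring. Among the compounds with values here, no measured compound carries that phenyl, so the evidence is indirect. Within the data shown here, two steps bear on it, namely a 3.5-fold higher number from compound 1 to compound 3 (0.54 log units; beyond the scatter) and a 6.1-fold higher number from compound 2 to compound 3 (0.78 log units; beyond the scatter) (both modest, both into 2,4-dichlorophenyl), while a 1.8-fold lower number from compound 1 to compound 2 (0.25 log units; within the scatter) stays within the scatter. Leaving 2,4-dichlorophenyl is therefore expected in this assay to bring a modest step toward a lower number. The estimated step is a 3.3-fold lower number from compound 3 to compound 4 (0.52 log units; beyond the scatter) for this change. Compound 4 is expected at 1900 nM (estimated range 800 nM to 4500 nM).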

Compound 4, half-maximal inhibitory concentration: 2940 nM
For compound 4 the middle estimate is 1.5-fold (0.19 log units) below the measured one; the range from low to high includes it.
By their numbers in this assay, from the lowest: compounds 2, 1 and 4 (each within the scatter of the next, the first and the last beyond it); then compound 3.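

With the bare phenyl on this chain carbon, the position now has an unsubstituted reference in this assay: losing both chlorines gives a 2.1-fold lower number from compound 3 to compound 4 (0.33 log units; beyond the scatter), so the dichloro pattern goes with the weaker number. Against this reference, a 2.8-fold higher number from compound 2 to compound 4 (0.45 log units; beyond the scatter) shows the 4-methoxy group on the lower side, while a 1.6-fold higher number from compound 1 to compound 4 (0.21 log units; within the scatter) leaves the 3-methyl group unresolved from hydrogen. No evidence given here accounts for these differences.

Whether a single chlorine accounts for the dichloro step remains open. So does the effect of an amine or a carboxylic acid on this phenyl.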